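Placing compound 4 beside its measured neighbours

This account rests on a few compounds, and the source may have more. Where it says the series, first, only, none or still open, it means among the compounds named here.

In a functional assay on MCF7 cells (Homo sapiens) for inhibition, read by CCK-8 assay, with a stated time of 48 h (on this read-out lower numbers stand for stronger inhibition and higher numbers for weaker inhibition), compound 1 (`COc1cc(-c2ccnc3cc(-c4cn(CO)c5ccccc45)nn23)cc(OC)c1OC`) gives 19 nM, compound 2 (`COc1cc(-c2ccnc3cc(-c4ccc(C)cc4)nn23)cc(OC)c1OC`) gives 47 nM and compound 3 (`Cn1ccc2cc(-c3cc4nccc(-c5ccc(F)cc5)n4n3)ccc21`) gives 4580 nM. Compound 2 is therefore second highest of the three, and its number lies beyond the scatter from both others. Compound 4 (`COc1cc(-c2ccnc3cc(-c4ccc5cc[nH]c5c4)nn23)cc(OC)c1OC`) departs from compound 2 at one place: 1H-indol-6-yl in place of 4-methylphenyl on an aromatic carbon. Among the measured compounds shown here, no measured step isolates this exchange. Compound 1 reaches 19 nM with a different group at this place, while compound 3 differs from compound 2 in more than this place and offers little guidance. The expected change in this assay is a 1.6-fold lower number from compound 2 to compound 4 (0.19 log units; within the scatter), a small move towards a lower number, probably within the scatter. Compound 4 is estimated at 30 nM, with an expected range of 8 nM to 120 nM.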

Compound 4, half-maximal inhibitory concentration: 23 nM
Compound 4: the middle estimate sits 1.3-fold (0.12 log units) above what was measured; low and high end bracket the measured number.
By their numbers in this assay, from the lowest: compounds 1 and 4 (each within the scatter of the next); then compound 2; then compound 3.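

In this assay, the place on the five-membered aromatic ring accepts 1H-indol-6-yl in place of 4-methylphenyl, giving a 2.0-fold lower number from compound 2 to compound 4 (0.31 log units; beyond the scatter). Among the compounds shown here, this is the first single-place step, and it shows that a two-ring group carrying a hydrogen-bond donor can replace a single carbon-only ring here with a modest gain.

As far as these compounds go, it remains open how an amine or a carboxylic acid on the phenyl ring would fare at this place. No available measurement explains the step.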